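The source may hold more compounds than are shown below. What is called first, only, known or untested is meant among the compounds shown, and "the series" means these compounds.

Measured in a functional assay on A549 cells (Homo sapiens) for inhibition, read by MTT assay, with a stated time of 48 h; a lower number here means a stronger inhibitor, a higher number a weaker inhibitor:
- Compound 1 `CCn1c(/C=C2\SC(=O)N(CC(=O)N3CCCCC3)C2=O)nc2ccccc21`: > 50000 nM, a limit of the assay
- Compound 2 `CCn1c(/C=C2\SC(=O)N(CC(=O)Nc3cc(C(C)(C)C)on3)C2=O)nc2ccccc21`: 44800 nM
- Compound 3 `CCn1c(/C=C2\SC(=O)N(CC(=O)N3CCCC3)C2=O)nc2ccccc21`: 31200 nM

Only compound 2 and compound 3 have actual numbers, and they lie within the scatter of each other, as a 1.4-fold lower number from compound 2 to compound 3 (0.16 log units; within the scatter) shows. Compound 1 gives only a limit. Its steps to the other two are floors, an at least 1.1-fold lower number from compound 1 to compound 2 (0.04 log units; that floor lies within the scatter) and an at least 1.6-fold lower number from compound 1 to compound 3 (0.20 log units; that floor lies within the scatter), and both floors lie within the scatter.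

Compound 4 `CC(C)n1c(/C=C2\SC(=O)N(CC(=O)Nc3cc(C(C)(C)C)on3)C2=O)nc2ccccc21` keeps the substituent on the carbonyl carbon of compound 2 and changes the other end of the molecule: methyl in place of hydrogen on a saturated chain carbon bound to an aromatic nitrogen and a saturated chain carbon. This is methyl in place of hydrogen on a saturated chain carbon bound to an aromatic nitrogen and a saturated chain carbon, so ethyl becomes isopropyl.

Among the compounds with values here, no measured step touches this place. Within the data shown here, all three changes sit on the carbonyl carbon, so they bear on it only indirectly, showing a series that sits close to the limit of this assay with a 1.4-fold lower number from compound 2 to compound 3 (0.16 log units; within the scatter) as its one fully measured step. On that basis no step beyond the scatter is expected in this assay. The expected step is small: a 1.3-fold lower number from compound 2 to compound 4 (0.11 log units; within the scatter).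

For compound 4 the estimated value is 35000 nM, with an expected range from 14000 nM to 50000 nM.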

Compound 4, half-maximal inhibitory concentration: > 50000 nM
Compound 4: a limit, no number (the forecaster's own chance of this, stated with the estimate: 30%); at least 1.4-fold (0.15 log units) between middle value and limit.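

In this assay compound 4 gives > 50000 nM, which is a limit of the assay and not a number. Within the data shown here, the change from ethyl to isopropyl is the first one at this place, and it gives an at least 1.1-fold higher number from compound 2 to compound 4 (0.04 log units; that floor lies within the scatter), so the earlier changes on the carbonyl carbon are now joined by a reading from the other end of the molecule, one that shows no lower number and leaves the true size of the step unknown. This place, like the piperidin-1-yl of compound 1, can therefore be read from one side only: the limit of > 50000 nM in this assay, at which 2 of the 4 values shown sit.

Left open is how a longer chain, a hydroxyethyl chain or an aminoethyl chain at this place would read in this assay, and whether any such group would give a step beyond the scatter from compound 2. Also open, from the compounds shown here alone, is whether isopropyl would read the same alongside pyrrolidin-1-yl on the carbonyl carbon, in place of the (5-(tert-butyl)-1,2-oxazol-3-yl)amino group that compound 4 carries.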